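The source may report more compounds than this note shows. Statements on the series, on what has been measured and on what is new or still open speak of the compounds shown alone.

Measured so far:
- Compound 1 `O=C(O)c1ccccc1-c1ccc(CCc2ncc(CC3CCC3)[nH]2)cc1`: 588 nM
- Compound 2 `Cc1ccc(Cc2cnc(CCc3ccc(-c4ccccc4C(=O)O)cc3)[nH]2)cc1`: 2660 nM

In an in vitro functional assay on cells for agonist activity at Bombesin receptor subtype-3 (Homo sapiens), read by luminescence and calcium flux (a lower number here means that less compound is needed, a higher number that more compound is needed for the effect), compound 2 gives 2660 nM, the higher of the two numbers recorded; compound 1 gives 588 nM. Within the data shown here, the one measured step, a 4.5-fold higher number from compound 1 to compound 2 (0.66 log units; beyond the scatter), is the only guide available, and it concerns an exchange of a saturated ring for an aromatic one at the saturated chain carbon bound to an aromatic carbon.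

Compound 3 `O=C(O)c1ccccc1-c1ccc(CCc2ncc(Cc3cccc(F)c3)[nH]2)cc1` differs from compound 2 by 3-fluorophenyl in place of 4-methylphenyl on a saturated chain carbon bound to an aromatic carbon. Among the measured compounds shown here, no measured pair exchanges one aromatic ring for another at this carbon, so the step from compound 1 to compound 2 bears on the change only indirectly: it shows that this position is sensitive to what sits there, and at a modest scale. With the aromatic ring kept and only its substituent altered, the expectation for compound 3 in this assay is a step of a 1.5-fold lower number from compound 2 to compound 3 (0.17 log units; within the scatter), most likely within or barely beyond the scatter, with no secure direction. Compound 3 is therefore estimated at 1800 nM, with a range of 500 nM to 6000 nM.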

Compound 3, half-maximal effective concentration: 159 nM
For compound 3 the middle estimate is 11-fold (1.05 log units) above the measured one, and the stated range ends above it.
By their numbers in this assay, from the lowest: compound 3; then compound 1; then compound 2.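

In this assay, an aromatic ring at this saturated chain carbon does not by itself give the higher number seen earlier: with the ring kept and only its substituent altered, there is a 17-fold lower number from compound 2 to compound 3 (1.22 log units; beyond the scatter). The 3-fluorobenzyl group also passes the cyclobutyl group, with a 3.7-fold lower number from compound 1 to compound 3 (0.57 log units; beyond the scatter), so the order of saturated and aromatic groups at this position depends on the substituent on the aromatic ring. Nothing available accounts for this change.

Fluorine and methyl differ here together with their place on the ring, so it remains open which of the two goes with the large step. Also open, on these data alone, is where an unsubstituted phenyl ring, an amine or a longer chain at this carbon would fall relative to these three compounds.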